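The source may hold more compounds than are shown below. What is called first, only, known or untested is meant among the compounds shown, and "the series" means these compounds.

Working notes on the series. Compound 1 `CCS(=O)(=O)Nc1ccc2c(c1)/C(=C(/Nc1ccc(C)cc1)c1ccccc1)C(=O)N2` sets the reference: in an ADME assay on HepG2 cells (Homo sapiens) for cytotoxicity, read by MTT assay, with a stated time of 48 h (on this read-out lower numbers stand for higher toxicity in this test and higher numbers for lower toxicity in this test), compound 1 gives 3.1 uM. Compound 2 `CC/C(Nc1ccc(CN2CCCCC2)cc1)=C1/C(=O)Nc2ccc(NS(=O)(=O)CC)cc21` reaches only a limit in this assay, > 6 uM (the limit of > 6 uM in this assay, at which 1 of the 3 values shown sits). Compound 3 `CCS(=O)(=O)Nc1ccc2c(c1)/C(=C(/NC1CCN(C)CC1)c1ccccc1)C(=O)N2` likewise stands at a limit in this assay, > 10 uM (the limit of > 10 uM in this assay, at which 1 of the 3 values shown sits), so compound 3 sits at the upper edge of the numbers shown, without an exact value. For the measured compounds named here, the one measured step, an at least 3.2-fold higher number from compound 1 to compound 3 (0.50 log units; beyond the scatter), lies beyond the scatter.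

Compound 4 `CCS(=O)(=O)Nc1ccc2c(c1)/C(=C(/Nc1ccccc1)c1ccccc1)C(=O)N2` differs from compound 3 by phenyl in place of 1-methylpiperidin-4-yl on an amine nitrogen. Compound 4 thus carries phenyl where compound 1 carries 4-methylphenyl on the same amine nitrogen, so the step from compound 1 to compound 3 bears on it most directly, and in reverse. Since an at least 3.2-fold higher number from compound 1 to compound 3 (0.50 log units; beyond the scatter) moved the number up, a return toward the number of compound 1 is expected, giving an expected step of an at least 2.8-fold lower number from compound 3 to compound 4 (0.45 log units; beyond the scatter) in this assay. For compound 4 the estimate in this assay is 3.5 uM, with an expected range from 1.5 uM to 8 uM.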

Compound 4, half-maximal toxic concentration: 4.7 uM
For compound 4 the middle estimate is 1.3-fold (0.13 log units) below the measured one; measured number inside the range.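

Exchanging 1-methylpiperidin-4-yl for phenyl on the amine nitrogen gives an at least 2.1-fold lower number from compound 3 to compound 4 (0.32 log units; beyond the scatter) in this assay, so the drop in the number also appears with an aromatic group that has no methyl. Phenyl and 4-methylphenyl on this nitrogen cannot be told apart in this assay, with a 1.5-fold higher number from compound 1 to compound 4 (0.18 log units; within the scatter), and the methyl on the aromatic carbon therefore shows no effect of its own here. From the compounds shown here alone, the full size of the step from the ring with the nitrogen to phenyl stays unknown because the entry for compound 3 is a limit and not a number: the limit of > 10 uM in this assay, at which 1 of the 4 values shown sits.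

Going by these compounds, it remains open whether the higher number follows the non-aromatic ring itself or its nitrogen. Cyclohexyl on the same amine nitrogen would separate the two, and piperidin-4-yl would test the role of the methyl on the ring nitrogen.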